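A few compounds are considered here, and "the series" means these few. Any claim that something is new, unique, unknown or untested is made for them only; others in the source may bear on it.

Measured so far:
compound 1 `O=C1NC(=O)c2c1c1c3cc(O)ccc3[nH]c1c1cccn21` — > 100000 nM
compound 2 `Cc1ccc2[nH]c3c4cn[nH]c4c4c(c3c2c1)C(=O)NC4=O` — > 100000 nM

In a functional assay on Hs 683 cells (Homo sapiens) for cytotoxicity, read by MTT assay, with a stated time of 72 h (on this read-out lower numbers stand for stronger inhibition and higher numbers for weaker inhibition), compound 2 gives > 100000 nM, which is a limit of the assay and not a number. Compound 1 likewise gives > 100000 nM, also a limit. Compound 2 thus stands at the limit of > 100000 nM in this assay, at which 2 of the 2 values shown sit. Compound 3 `O=C1NC(=O)c2c1c1[nH]ncc1c1[nH]c3ccccc3c21` differs from compound 2 by hydrogen in place of methyl on an aromatic carbon. Among the measured compounds shown here, no step between measured compounds is available, so the expected change is none beyond the scatter. Compound 3 is therefore expected to remain at the limit, estimated at 200000 nM with a range of 60000 nM to 1000000 nM. The expected step is a step that the limit leaves unreadable from compound 2 to compound 3.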

Compound 3, half-maximal inhibitory concentration: 93000 nM
For compound 3 the middle estimate is 2.2-fold (0.33 log units) above the measured one; low and high end bracket the measured number.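

In this assay, hydrogen in place of methyl on an aromatic carbon gives an at least 1.0-fold lower number from compound 2 to compound 3 (0.03 log units; that floor lies within the scatter), so no change at this position is shown beyond the scatter. Among the compounds shown here, compound 3, at 93000 nM, gives the first value here that is a number and not a limit. The real size of the step cannot be read past that floor: the limit of > 100000 nM in this assay, at which 2 of the 3 values shown sit.

Still open, as far as these compounds go, is whether another group on this aromatic carbon, such as an amine, a carboxylic acid or a longer chain, would move the value clearly away from that limit.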